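The source may hold more compounds than are shown below. What is called first, only, known or untested is meant among the compounds shown, and "the series" means these compounds.

Measured in an ADME assay on L6 cells (Rattus norvegicus) for cytotoxicity, read by resazurin assay, with a stated time of 70 h; a lower number here means a stronger inhibitor, a higher number a weaker inhibitor:
- compound 1 `CC(=O)Oc1ccc2c(c1)C(C)=CC(C)(C)N2Cc1ccccc1`: 24000 nM
- compound 2 `CC(=O)Oc1ccc2c(c1)C(C)=CC(C)(C)N2Cc1ccc(C)cc1`: 21000 nM

In this assay compound 2 gives 21000 nM, and this lies within the scatter of compound 1, so the two are not separated. Compound 3 `CC(=O)Oc1ccc2c(c1)C(C)=CC(C)(C)N2Cc1ccc(Cl)c(Cl)c1` is the next step: 3,4-dichlorophenyl in place of 4-methylphenyl on a saturated chain carbon bound to a nitrogen on an aromatic ring in a ring. Among the measured compounds shown here, only one measured step bears on this, a 1.1-fold lower number from compound 1 to compound 2 (0.06 log units; within the scatter), a methyl in place of hydrogen on an aromatic carbon. For the measured compounds named here, no chlorine-bearing compound has been measured, so the evidence is thin. With that single step within the scatter, no change beyond the scatter is expected. The expected step is a 1.4-fold lower number from compound 2 to compound 3 (0.15 log units; within the scatter). For compound 3 the estimated value is 15000 nM, with an expected range of 7000 nM to 30000 nM.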

Compound 3, half-maximal inhibitory concentration: 28000 nM
Compound 3: middle estimate off by 1.9-fold (0.27 log units), on the low side; the measured number falls inside the stated range.
By their numbers in this assay, from the lowest: compounds 2, 1 and 3 (each within the scatter of the next).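

In this assay, 3,4-dichlorophenyl on a saturated chain carbon bound to a nitrogen on an aromatic ring in a ring stays within the scatter against both earlier groups: 4-methylphenyl (a 1.3-fold higher number from compound 2 to compound 3 (0.12 log units; within the scatter)) and phenyl (a 1.2-fold higher number from compound 1 to compound 3 (0.07 log units; within the scatter)). The position thus now tolerates two chlorines as well as a methyl with no separation among compound 1, compound 2 and compound 3, so neither kind of substituent has yet moved the number beyond the scatter. No independent measurement bears on why this position reads so flat.

Open, as far as these compounds go, is whether any group here can separate from these three, for instance an amine or a carboxylic acid on the phenyl. A longer chain in place of the saturated chain carbon, or a different group in place of the acetate on the shared core, is equally untested by the compounds shown.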